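A 2,5-dichlorophenyl swap on a sulfonamide nitrogen

The source may hold more compounds than are shown below. What is called first, only, known or untested is meant among the compounds shown, and "the series" means these compounds.

In a functional assay on cells (leukaemia cell line, Homo sapiens) for inhibition, read by sulforhodamine B assay, with a stated time of 48 h (a lower number here means a stronger inhibitor of growth, a higher number a weaker inhibitor of growth), compound 3 `Cc1ccc(NS(=O)(=O)c2ccc(-c3cnc(C4CC4)o3)cc2)cc1C` gives 420 nM. That value sits close to those of compound 1 `O=S(=O)(Nc1ccc(F)c(Cl)c1)c1ccc(-c2cnc(C3CC3)o2)cc1`, at 260 nM, and compound 2 `O=S(=O)(Nc1ccc(Cl)c(F)c1)c1ccc(-c2cnc(C3CC3)o2)cc1`, at 380 nM, so the three cannot be ranked. They share one core and differ only in the phenyl group on a sulfonamide nitrogen.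

Compound 4 `O=S(=O)(Nc1cc(Cl)ccc1Cl)c1ccc(-c2cnc(C3CC3)o2)cc1` carries 2,5-dichlorophenyl in place of 3,4-dimethylphenyl on a sulfonamide nitrogen.

Among the compounds with values here, two measured steps bear most directly on this change. Each exchanges a halogen-bearing phenyl group with 3,4-dimethylphenyl. They are a 1.6-fold higher number from compound 1 to compound 3 (0.21 log units; within the scatter) and a 1.1-fold higher number from compound 2 to compound 3 (0.04 log units; within the scatter). Moving the halogens between compound 1 and compound 2 also made little difference, with a 1.5-fold higher number from compound 1 to compound 2 (0.16 log units; within the scatter). Within the data shown here, no measured compound carries a 2,5-dichlorophenyl group, however, so these steps are only an indirect guide and the range must stay wide.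

In this assay, no step beyond the scatter is therefore expected, and the estimate is a 1.1-fold lower number from compound 3 to compound 4 (0.02 log units; within the scatter). For compound 4 the estimated value is 400 nM, with an expected range of 150 nM to 1100 nM.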

Compound 4, concentration for 50% growth inhibition: 1020 nM
Compound 4: the middle estimate sits 2.6-fold (0.41 log units) below what was measured; the range from low to high includes it.
By their numbers in this assay, from the lowest: compounds 1, 2 and 3 (each within the scatter of the next); then compound 4.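

Until now, every exchange of the phenyl group on a sulfonamide nitrogen had stayed within the scatter, so this place could have seemed indifferent to the choice of group. In this assay, within the data shown here, 2,5-dichlorophenyl is the first group here to produce steps beyond the scatter, and all three are modest: a 2.4-fold higher number from compound 3 to compound 4 (0.39 log units; beyond the scatter), a 2.7-fold higher number from compound 2 to compound 4 (0.43 log units; beyond the scatter) and a 3.9-fold higher number from compound 1 to compound 4 (0.59 log units; beyond the scatter), which make compound 4 the weakest inhibitor of growth of the four. The heavy-atom, donor and acceptor counts are the same for 3,4-dimethylphenyl and 2,5-dichlorophenyl, so those counts do not separate the two groups, and no measurement at hand explains the rise.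

The compounds shown leave open whether the rise follows from having two chlorines on the ring or from where those chlorines sit, since compound 4 alone carries two of them. A phenyl group with a single chlorine, or one with a methoxy group or an amine in place of the chlorines, would show how far this trend extends at the sulfonamide nitrogen.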